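The source may report more compounds than this note shows. Statements on the series, on what has been measured and on what is new or still open speak of the compounds shown alone.

Working notes on the series. A common core is carried through compound 1 `O=C(/C=C/c1ccc2c(c1)B(O)OC2)c1ccccc1`, compound 2 `O=C(/C=C/c1ccc2c(c1)B(O)OC2)c1ccco1` and compound 3 `Cc1ccc(C(=O)/C=C/c2ccc3c(c2)B(O)OC3)cc1`, which differ only in the aryl group on the carbonyl carbon. In a functional assay on HCT-116 cells (Homo sapiens) for cytotoxicity, read by MTT assay, with a stated time of 48 h (on this read-out lower numbers stand for stronger inhibition and higher numbers for weaker inhibition), compound 1 gives 6100 nM, compound 2 gives 24100 nM and compound 3 gives 10500 nM. Compound 3 therefore stands second highest of the three numbers. Its nearest neighbour is compound 1: the step of a 1.7-fold higher number from compound 1 to compound 3 (0.24 log units; within the scatter) lies within the scatter, so no order between the two can be claimed. Its furthest neighbour is compound 2, reached by a 2.3-fold lower number from compound 2 to compound 3 (0.36 log units; beyond the scatter). The largest step within the set is a 4.0-fold higher number from compound 1 to compound 2 (0.60 log units; beyond the scatter).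

Compound 4 `O=C(/C=C/c1ccc2c(c1)B(O)OC2)c1ccc(C(F)(F)F)cc1` is not yet measured. It differs from compound 3 by trifluoromethyl in place of methyl on an aromatic carbon. Going by the values given here, no measured step introduces a trifluoromethyl anywhere, so the evidence is indirect: the one change at the same aromatic carbon, from compound 1 to compound 3, stayed within the scatter, and the two exchanges of the whole aryl group on the carbonyl carbon were only modest. On that basis the expected step in this assay from compound 3 to compound 4 is small, possibly none beyond the scatter, with no firm direction. Compound 4 is estimated at 9000 nM, with a range of 3500 nM to 23000 nM. That expectation corresponds to a step of a 1.2-fold lower number from compound 3 to compound 4 (0.07 log units; within the scatter).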

Compound 4, half-maximal inhibitory concentration: 6300 nM
The estimate for compound 4 lay 1.4-fold (0.15 log units) above the measured number; measured number inside the range.
By their numbers in this assay, from the lowest: compounds 1, 4 and 3 (each within the scatter of the next); then compound 2.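

At the aromatic carbon para to a large group, the step of a 1.7-fold lower number from compound 3 to compound 4 (0.22 log units; within the scatter) and the step of a 1.0-fold higher number from compound 1 to compound 4 (0.01 log units; within the scatter) in this assay show that trifluoromethyl, with four heavy atoms against one for methyl, also gives no separation beyond the scatter from either methyl or hydrogen, so hydrogen, methyl and trifluoromethyl at this carbon cannot be put in any order. Within the compounds shown, a change at this carbon has therefore not moved the number beyond the scatter, whereas the exchange of the whole aryl group for furan-2-yl did, with the step of a 4.0-fold higher number from compound 1 to compound 2 (0.60 log units; beyond the scatter) remaining the largest measured in the set. No measurement shown bears on why the three substituents at this carbon give numbers within the scatter of one another.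

As far as these compounds go, whether this carbon stays as flat with a group that carries a hydrogen-bond donor or a charge, such as an amine or a carboxylic acid, or with a longer chain, stays open. From the compounds shown here alone, the same substituents at other carbons of the six-membered aromatic ring are also open, as is whether the flat picture holds on any other cell line.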